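The source may hold more compounds than are shown below. What is called first, only, known or untested is meant among the compounds shown, and "the series" means these compounds.

Measured compounds:
compound 1, `O=C(CN1CN(c2ccccc2)C2(CCN(C(=O)c3ccc(C4CCCCC4)cc3)CC2)C1=O)NCCO`, 2000 nM in an assay on HEK293 cells for displacement of a labelled ligand from NPC1-like intracellular cholesterol transporter 1 (Homo sapiens); on this read-out lower numbers stand for stronger inhibition and higher numbers for weaker inhibition;
compound 2, `O=C(CN1CN(c2ccccc2)C2(CCN(C(=O)c3ccc(C4CCCCC4)cc3)CC2)C1=O)N1CCCCC1`, 1100 nM.

Compound 2 has the lowest of the two numbers, with compound 1 next to it at a 1.8-fold lower number from compound 1 to compound 2 (0.26 log units; within the scatter), a step that stays within the scatter. The unmeasured compound 3, `NCCNC(=O)CN1CN(c2ccccc2)C2(CCN(C(=O)c3ccc(C4CCCCC4)cc3)CC2)C1=O`, differs from compound 2 in one place: (2-aminoethyl)amino in place of piperidin-1-yl on a carbonyl carbon. Among the compounds with values here, only one measured step bears on this change, the one from compound 1 to compound 2, in which a (2-hydroxyethyl)amino group was exchanged for piperidin-1-yl on the same carbonyl carbon and the number moved only within the scatter. Because a 1.8-fold lower number from compound 1 to compound 2 (0.26 log units; within the scatter) was that small, compound 3, which carries an open chain with hydrogen-bond donors like compound 1, is expected to sit near compound 1 rather than away from both. The estimate for compound 3 is 1800 nM, within 800 nM to 4500 nM, an expected step of a 1.6-fold higher number from compound 2 to compound 3 (0.21 log units; within the scatter).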

Compound 3, half-maximal inhibitory concentration: 3800 nM
Compound 3: middle estimate off by 2.1-fold (0.32 log units), on the low side; the range from low to high includes it.
By their numbers in this assay, from the lowest: compounds 2, 1 and 3 (each within the scatter of the next, the first and the last beyond it).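

In this assay, this carbonyl carbon proves able to carry a change beyond the scatter: (2-aminoethyl)amino in place of piperidin-1-yl gives a 3.5-fold higher number from compound 2 to compound 3 (0.54 log units; beyond the scatter) here, whereas the earlier exchange at the same place stayed within it. Amino in place of hydroxy on the open chain gives a 1.9-fold higher number from compound 1 to compound 3 (0.28 log units; within the scatter) and so does not separate the two chains, which leaves compound 2 and compound 3 as the only pair lying beyond the scatter of each other. Nothing available explains this difference.

Going by these compounds, it remains open whether a small open group such as methylamino would track the chains or compound 2, which would help separate the loss of the ring from the entry of the amine. Also open, on these data alone, is how a morpholin-4-yl ring, a carboxylic acid or a longer chain would behave on this carbonyl carbon.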